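Saturating the alkoxy chain on the shared core

The compounds below may be only part of what the source reports. "The series", "measured", "known", "first", "only" and "open" are said of these compounds alone.

Compound 1 `CC/C=C\COC1(c2ccc(Cl)cc2)SC=C(C)n2c1noc2=O` is the only numbered point in a functional assay on A2780 cells (Homo sapiens) for antiproliferative activity, read by MTT assay, with a stated time of 3 days; on this read-out higher numbers stand for weaker inhibition and lower numbers for stronger inhibition; in this assay compound 1 gives 55000 nM. Compound 2 `CCCCCCCCCCCCCCCCCCOC1(c2ccc(Br)cc2)SC=C(C)n2c1noc2=O` sits at the limit of > 100000 nM in this assay, at which 1 of the 2 values shown sits; in this assay compound 2 gives > 100000 nM, which is a limit and not a number. Compound 3 `CCCCCOC1(c2ccc(Cl)cc2)SC=C(C)n2c1noc2=O` differs from compound 1 by butyl in place of but-1-en-1-yl on a saturated chain carbon bound to an oxygen on a saturated carbon. For the measured compounds named here, no step between measured compounds is available to calibrate this change, so the expected step is a 1.1-fold higher number from compound 1 to compound 3 (0.04 log units; within the scatter), none beyond the scatter. Compound 3 is estimated in this assay at 60000 nM, with a range from 25000 nM to 150000 nM.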

Compound 3, half-maximal inhibitory concentration: > 100000 nM
Compound 3 gave a limit, no number; the forecaster's own chance of this, stated with the estimate: 25%; middle value at least 1.6-fold (0.22 log units) from the limit.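

In this assay, replacing pent-2-en-1-yl with pentyl on the shared core gives an at least 1.8-fold higher number from compound 1 to compound 3 (0.25 log units; that floor lies within the scatter). The value of compound 3 is a limit, so this step is only a floor, and the true size of the change at this oxygen-bound chain cannot be read. Compound 1 remains the only compound with a number, and values at the limit now predominate: the limit of > 100000 nM in this assay, at which 2 of the 3 values shown sit.

As far as these compounds go, how far compound 3 lies from compound 1 remains open. So does whether a shorter chain such as ethyl, or a chain ending in an amine, would give a number below the limit.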